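From 3-(hydroxymethyl)phenyl to 4-carbamoylphenyl

This account rests on a few compounds, and the source may have more. Where it says the series, first, only, none or still open, it means among the compounds named here.

In a functional assay on A549 cells (Homo sapiens) for inhibition, read by sulforhodamine B assay, with a stated time of 48 h, tested at 50 uM (a lower number here means less inhibition of growth, a higher number more inhibition of growth at the concentration tested), compound 1 `COc1ccc([C@@H]2C/C(=N/OCc3cn(-c4ccc(O)cc4)nn3)c3cc(CC=C(C)C)c(OC)cc3O2)cc1` gives 52%, compound 2 `COc1ccc([C@@H]2C/C(=N/OCc3cn(-c4ccc(C#N)cc4)nn3)c3cc(CC=C(C)C)c(OC)cc3O2)cc1` gives 42% and compound 3 `COc1ccc([C@@H]2C/C(=N/OCc3cn(-c4cccc(CO)c4)nn3)c3cc(CC=C(C)C)c(OC)cc3O2)cc1` gives 43%, which places compound 3 within the scatter of both others. Compound 4 `COc1ccc([C@@H]2C/C(=N/OCc3cn(-c4ccc(C(N)=O)cc4)nn3)c3cc(CC=C(C)C)c(OC)cc3O2)cc1` differs from compound 3 at one place: 4-carbamoylphenyl in place of 3-(hydroxymethyl)phenyl on an aromatic nitrogen. There, 4-carbamoylphenyl stands in place of 3-(hydroxymethyl)phenyl on an aromatic nitrogen. The three measured steps all change the group at this same place, and none leaves the scatter: a number 10 percentage points lower from compound 1 to compound 2 (within the scatter), a number 9 percentage points lower from compound 1 to compound 3 (within the scatter) and a number 1 percentage points higher from compound 2 to compound 3 (within the scatter). No step beyond the scatter is therefore expected in this assay. The expected step is a number 3 percentage points higher from compound 3 to compound 4 (within the scatter). The estimated value for compound 4 is 46%, with an expected range of 34% to 58%.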

Compound 4, percent growth inhibition at one concentration: 100%
Compound 4: the middle estimate sits 54 percentage points below what was measured; the measured number lies above the stated range.
By their numbers in this assay, from the lowest: compounds 2, 3 and 1 (each within the scatter of the next); then compound 4.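

At this place on the aromatic nitrogen, the earlier groups had given no step beyond the scatter, whereas in this assay the new group gives a number 57 percentage points higher from compound 3 to compound 4 (beyond the scatter) as a large step. On the aromatic carbon, carbamoyl also gives a number 58 percentage points higher from compound 2 to compound 4 (beyond the scatter) in place of cyano and a number 48 percentage points higher from compound 1 to compound 4 (beyond the scatter) in place of hydroxy, so the large step follows carbamoyl against all three groups shown. No available evidence accounts for this rise.

On these data alone, it remains open whether a carboxylic acid or a methyl ester in place of carbamoyl would keep the high number. As far as these compounds go, it also remains open whether 3-carbamoylphenyl would do the same as 4-carbamoylphenyl.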